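One added methoxy on the aryl group of compound 1

The compounds below may be only part of what the source reports. "The series", "measured", "known", "first", "only" and "open" are said of these compounds alone.

In a functional assay on CCRF-CEM cells (Homo sapiens) for antiproliferative activity (on this read-out lower numbers stand for stronger inhibition and higher numbers for weaker inhibition), compound 1 (`COc1ccc(-c2cc(N)c(C(=O)c3cc(OC)c(OC)c(OC)c3)s2)cc1OC`) gives 20 nM and compound 2 (`COc1cc(C(=O)c2sc(-c3ccc(F)cc3)cc2N)cc(OC)c1OC`) gives 15 nM so the two stand within the scatter of each other. Compound 3 (`COc1cc(C(=O)c2sc(-c3cc(OC)c(OC)c(OC)c3)cc2N)cc(OC)c1OC`) differs from compound 1 by methoxy in place of hydrogen on an aromatic carbon and has not yet been measured. Within the data shown here, the only measured step bearing on this is a 1.3-fold lower number from compound 1 to compound 2 (0.12 log units; within the scatter) when 4-fluorophenyl replaces 3,4-dimethoxyphenyl, and it stays small. Only a small change is therefore expected, an estimated 1.5-fold higher number from compound 1 to compound 3 (0.18 log units; within the scatter) and no move beyond the scatter. For compound 3 the estimated value is 30 nM with an expected range from 8 nM to 110 nM as a first guess.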

Compound 3, half-maximal inhibitory concentration: 840 nM
Compound 3: middle estimate off by 28-fold (1.45 log units), on the low side; measured number above the stated range.
By their numbers in this assay, from the lowest: compounds 2 and 1 (each within the scatter of the next); then compound 3.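

In this assay, methoxy in place of hydrogen on an aromatic carbon gives a 42-fold higher number from compound 1 to compound 3 (1.62 log units; beyond the scatter), so this single position, ortho to a methoxy group and meta to a large group, strongly affects activity. The earlier step from 3,4-dimethoxyphenyl to 4-fluorophenyl stayed within the scatter and gave no hint that one change on this aryl group could weaken inhibition so much. No measurement available here explains the loss. Going by these compounds, it remains open whether a methyl or hydroxyl group at this position would cost as much as methoxy does.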